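The source may hold more compounds than are shown below. What is called first, only, known or untested is meant among the compounds shown, and "the series" means these compounds.

Series notes on cytotoxicity. Compound 1 `COC(=O)C[C@H](NC(=O)OC(C)(C)C)C(=O)NC1(C(=O)NCc2ccccc2)CCN(Cc2ccccc2)CC1` carries hydrogen on the amide-type nitrogen; in an ADME assay on MDCK cells (Canis lupus familiaris) for cytotoxicity, read by microscopy, with a stated time of 72 h (on this read-out lower numbers stand for higher toxicity in this test and higher numbers for lower toxicity in this test), compound 1 gives 100000 nM. For the measured compounds named here, compound 2 `COC(=O)C[C@H](NC(=O)OC(C)(C)C)C(=O)N(C1CC1)C1(C(=O)NCc2ccccc2)CCN(Cc2ccccc2)CC1` places cyclopropyl on that nitrogen, and in this assay compound 2 gives 84000 nM, the lowest of the two numbers so far, with compound 1 nearest; the step of a 1.2-fold lower number from compound 1 to compound 2 (0.08 log units; within the scatter) stays within the scatter. Compound 3 `COC(=O)C[C@H](NC(=O)OC(C)(C)C)C(=O)N(Cc1ccccc1F)C1(C(=O)NCc2ccccc2)CCN(Cc2ccccc2)CC1` is not yet measured; its change from compound 2 is 2-fluorobenzyl in place of cyclopropyl on an amide-type nitrogen. Going by the values given here, only one measured step touches this nitrogen, a 1.2-fold lower number from compound 1 to compound 2 (0.08 log units; within the scatter), and it is small; a 2-fluorobenzyl entering here has no measured precedent. The expectation for compound 3 in this assay is therefore a step of about a 1.2-fold lower number from compound 2 to compound 3 (0.08 log units; within the scatter), not beyond the scatter. Compound 3 is estimated at 70000 nM in this assay, with a range from 30000 nM to 150000 nM.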

Compound 3, minimum cytotoxic concentration: 20000 nM
Compound 3: middle estimate off by 3.5-fold (0.54 log units), on the high side; measured number below the stated range.
By their numbers in this assay, from the lowest: compound 3; then compounds 2 and 1 (each within the scatter of the next).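

This amide-type nitrogen is not indifferent in this assay: the step with 2-fluorobenzyl in place of cyclopropyl is a 4.2-fold lower number from compound 2 to compound 3 (0.62 log units; beyond the scatter) and the step with 2-fluorobenzyl in place of the amide hydrogen is a 5.0-fold lower number from compound 1 to compound 3 (0.70 log units; beyond the scatter), whereas the earlier step from hydrogen to cyclopropyl stayed within the scatter. Substitution at this nitrogen therefore does not by itself shift the number; the modest move toward higher toxicity in this test appears only with 2-fluorobenzyl. Nothing on hand bears on the reason for this shift.

The compounds shown do not separate the contribution of the fluorine from that of the benzyl, which a plain benzyl on this nitrogen would address. From the compounds shown here alone, whether a longer alkyl chain or a substituent carrying an amine would move the number in the same direction also remains open.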